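This account rests on a few compounds, and the source may have more. Where it says the series, first, only, none or still open, it means among the compounds named here.

Working notes on the series. In a functional assay on HeLa cells (Homo sapiens) for antiproliferative activity, read by MTT assay, with a stated time of 48 h (on this read-out higher numbers stand for weaker inhibition and lower numbers for stronger inhibition), compound 1 (`Cc1nc2cc(Cl)ccc2nc1Oc1ccc(C(=O)N[C@@H](C)C(=O)O)cc1`) gives 30000 nM as a measured number. Compound 2 (`COC(=O)CNC(=O)c1ccc(Oc2nc3ccccc3nc2NC(C)(C)C)cc1`) stands at > 50000 nM and this is a limit of the assay, not a number. Compound 3 (`CC(C)C[C@H](NC(=O)c1ccc(Oc2nc3ccccc3nc2NC(C)(C)C)cc1)C(=O)O`) differs from compound 2 in one place, on an amide-type nitrogen (1-carboxy-3-methylbutyl in place of (methoxycarbonyl)methyl on an amide-type nitrogen), where 1-carboxy-3-methylbutyl replaces (methoxycarbonyl)methyl and one defined stereocentre enters. Among the measured compounds shown here, no measured step gives the size of this change. In this assay a small shift toward stronger inhibition is expected, or none beyond the scatter. For the measured compounds named here, compound 1 at 30000 nM is the only measured number to lean on, so the expectation stays in that range. The expected change an at least 1.1-fold lower number from compound 2 to compound 3 (0.07 log units; that floor lies within the scatter) remains rough, and a further limit would be no surprise. For compound 3 the estimated value is 42000 nM with an expected range from 15000 nM to 90000 nM in this read-out.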

Compound 3, half-maximal inhibitory concentration: 39200 nM
Compound 3: the middle estimate sits 1.1-fold (0.03 log units) above what was measured; the range from low to high includes it.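

At the amide-type nitrogen, 1-carboxy-3-methylbutyl in place of (methoxycarbonyl)methyl gives a measured number on this core: in this assay compound 3 reads 39200 nM. Compound 2 stands at > 50000 nM, which is a limit of the assay and not a number. The change can be read only as an at least 1.2-fold lower number from compound 2 to compound 3 (0.10 log units; that floor lies within the scatter), a floor and not a size, and the true size of the step stays unknown because one end of it is a limit: the limit of > 50000 nM in this assay, at which 1 of the 3 values shown sits.

Open, as far as these compounds go, is which part of the change counts: the methyl ester of 1-carboxy-3-methylbutyl, or a plain carboxymethyl group on the same nitrogen, would separate the carboxylic acid from the longer chain. Also open, from the compounds shown here alone, is how an amine in place of the carboxylic acid on that chain would read in this assay.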